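Swapping a fluorine for a chlorine on the benzoyl ring

This account rests on a few compounds, and the source may have more. Where it says the series, first, only, none or still open, it means among the compounds named here.

Compound 2 `O=C(NC(=S)N1CCc2c(OCCCCCOc3ccc(Cl)cc3)cccc21)c1ccc(F)cc1` and compound 1 `O=C(NC(=S)N1CCc2c(OCCCCCOc3ccc(Cl)cc3)cccc21)c1ccc([N+](=O)[O-])cc1` share one core and differ only in the group on the benzoyl ring. In an ADME assay on Huh-7 cells (Homo sapiens) for cytotoxicity (a higher number here means that more compound is tolerated, a lower number that less compound is tolerated), compound 1 gives 13600 nM, while compound 2 gives 31100 nM, the higher of the two numbers, so it is the better tolerated of the pair. Among the measured compounds shown here, the one measured step, a 2.3-fold higher number from compound 1 to compound 2 (0.36 log units; beyond the scatter), exchanges a nitro for a fluoro. Compound 3 `O=C(NC(=S)N1CCc2c(OCCCCCOc3ccc(Cl)cc3)cccc21)c1ccc(Cl)cc1` takes the next change: chloro in place of fluoro on an aromatic carbon. For the measured compounds named here, no measured pair shows a halogen exchanged for another halogen, so the only step available speaks to a different change and gives little guidance here. The step from compound 2 to compound 3 is therefore expected to be small, likely within the usual scatter: a 1.1-fold lower number from compound 2 to compound 3 (0.05 log units; within the scatter). For compound 3 the estimated value in this assay is 28000 nM, with a range from 12000 nM to 60000 nM.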

Compound 3, half-maximal cytotoxic concentration: 21700 nM
Beside the measured number, compound 3's estimate is 1.3-fold (0.11 log units) above it; measured number inside the range.
By their numbers in this assay, from the lowest: compounds 1, 3 and 2 (each within the scatter of the next, the first and the last beyond it).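

In this assay the exchange of fluoro for chloro on this aromatic carbon, para to a large group, gives a 1.4-fold lower number from compound 2 to compound 3 (0.16 log units; within the scatter) and so does not separate the two halogens. Chloro in place of nitro gives a 1.6-fold higher number from compound 1 to compound 3 (0.20 log units; within the scatter) as well, which means compound 3 cannot be told apart from either of the others, even though compound 1 and compound 2 do differ beyond the scatter. Nothing available here explains why the numbers fall this way.

On these data alone, whether an amine, a carboxylic acid or a methoxy group at the same position would stay in this range remains open. The three compounds also leave open how a shorter or longer chain elsewhere on the shared core would change the tolerated concentration.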